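Aryl variation on the shared core, cytotoxicity notes

A few compounds are considered here, and "the series" means these few. Any claim that something is new, unique, unknown or untested is made for them only; others in the source may bear on it.

Compound 3 `O=c1oc2ccccc2c2nc3c(ccc4cc[nH]c43)c(-c3ccccc3)c12` carries a phenyl on the shared core. In a functional assay on B16-F10 cells (Mus musculus) for cytotoxicity (a lower number here means a stronger inhibitor, a higher number a weaker inhibitor), compound 3 gives 70700 nM, level with compound 1 `O=c1oc2ccccc2c2nc3c(ccc4cc[nH]c43)c(-c3ccc(C(F)(F)F)cc3)c12` at 70700 nM and with compound 2 `O=c1oc2ccccc2c2nc3c(ccc4cc[nH]c43)c(-c3ccc(Cl)cc3Cl)c12` at 70700 nM. Every step among these three lies within the scatter: no change at the digits printed from compound 1 to compound 3 (within the scatter), no change at the digits printed from compound 2 to compound 3 (within the scatter) and no change at the digits printed from compound 1 to compound 2 (within the scatter). Compound 4 `O=c1oc2ccccc2c2nc3c(ccc4cc[nH]c43)c(-c3c(Cl)cccc3Cl)c12` differs from compound 3 by 2,6-dichlorophenyl in place of phenyl on an aromatic carbon. Chlorine on the aryl group already appears in compound 2 without a step beyond the scatter, as no change at the digits printed from compound 2 to compound 3 (within the scatter) shows, so in this assay no step beyond the scatter is expected from this change. The expected step from compound 3 to compound 4 is estimated as no change at the digits printed from compound 3 to compound 4 (within the scatter). For compound 4 the estimate in this assay is 70700 nM, with a range from 35000 nM to 141000 nM.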

Compound 4, half-maximal inhibitory concentration: 70700 nM
For compound 4 middle estimate and measured number coincide at the digits printed, within the range that was stated.
By their numbers in this assay, from the lowest: compounds 1, 2, 3 and 4 (each within the scatter of the next).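

Chlorine on both sides of the aryl attachment, as in 2,6-dichlorophenyl, leaves the read-out in this assay unmoved: no change at the digits printed from compound 3 to compound 4 (within the scatter), no change at the digits printed from compound 2 to compound 4 (within the scatter) and no change at the digits printed from compound 1 to compound 4 (within the scatter). The dichlorophenyl groups of compound 2 and compound 4 are therefore not told apart here, and all four aryl groups at this position share one printed value. No evidence on a cause bears on this result.

From the compounds shown here alone, whether an amine or a carboxylic acid on the aryl group, or a longer chain in its place, would give a step beyond the scatter stays open.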